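This account rests on a few compounds, and the source may have more. Where it says the series, first, only, none or still open, it means among the compounds named here.

The measured compounds and their values in a functional assay on NUGC-3 cells (Homo sapiens) for inhibition, read by sulforhodamine B assay, with a stated time of 48 h; on this read-out higher numbers stand for weaker inhibition of growth and lower numbers for stronger inhibition of growth:

Compound 1, `O=C(Nc1cccc(O)c1)c1nccc2ccccc12`, gives > 10000 nM, which is a limit of the assay and not a number.
Compound 2, `O=C(Nc1cccc(C(F)(F)F)c1)c1nccc2ccccc12`, gives > 10000 nM, again a limit rather than a number.
Compound 3, `O=C(Nc1cccc(O)c1)C1NCCc2ccccc21`, gives > 10000 nM, also a limit.

Compound 1 and compound 2 share one core and differ in a single place: trifluoromethyl in place of hydroxy on an aromatic carbon. Within the data shown here, both values are limits, so the step that the two limits leave unreadable from compound 1 to compound 2 cannot be read; the measurements show only that neither compound reached measurable growth inhibition in this assay.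

Compound 3 carries the same hydroxy-bearing ring as compound 1 on a different core; the difference between the two cores is not broken down here. Compound 4, `O=C(Nc1cccc(C(F)(F)F)c1)C1NCCc2ccccc21`, has not yet been measured. It stands to compound 3 as compound 2 stands to compound 1: trifluoromethyl in place of hydroxy on an aromatic carbon. The change is the same in both pairs, including where on the ring it sits.

For this assay the step from compound 3 to compound 4 is expected to be a step that the limit leaves unreadable from compound 3 to compound 4, set beside the unreadable earlier step that the two limits leave unreadable from compound 1 to compound 2. Among the measured compounds shown here, that expectation rests on (the limit of > 10000 nM in this assay, at which 3 of the 3 values shown sit), since every value so far sits at that same limit and the identical change on the other core produced nothing readable. Compound 4 is therefore expected to give about 20000 nM, between 7000 nM and 80000 nM, most likely reported once more as a limit only.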

Compound 4, concentration for 50% growth inhibition: > 10000 nM
Compound 4: a limit, no number (the forecaster's own chance of this, stated with the estimate: 85%); the middle value lies beyond the limit too.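

In this assay compound 4 gives > 10000 nM, which is a limit and not a number. Compound 3 also sits at a limit, so no new step can be read between compound 3 and compound 4. The compounds shown leave open which change in structure, if any, would give a measurable growth inhibition, as every result so far is the same limit: the limit of > 10000 nM in this assay, at which 4 of the 4 values shown sit.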